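Swapping the Benzofuranyl Arm of Compound 1 for Cyanophenyl

The source may hold more compounds than are shown below. What is called first, only, known or untested is meant among the compounds shown, and "the series" means these compounds.

Compound 1 `O=C1C=CC2(C=C1)OC(=O)C(c1cc3ccccc3o1)=C2c1ccccc1` gives 66600 nM in an ADME assay on MEpiC cells (Homo sapiens) for antiproliferative activity, read by MTT assay, with a stated time of 48 h; on this read-out higher numbers stand for weaker inhibition and lower numbers for stronger inhibition.
Compound 2 `O=C1C=CC2(C=C1)OC(=O)C(c1ccc([N+](=O)[O-])cc1)=C2c1ccccc1` gives 66600 nM in this assay.
Compound 3 `COc1c(Br)cc(C)cc1C1=C(c2ccccc2)C2(C=CC(=O)C=C2)OC1=O` gives 14700 nM in this assay.

Compound 1 stands level with compound 2 at the digits shown; together they give the highest numbers of the three. Among the compounds with values here, compound 3 gives a lower number than compound 1, a gap that lies beyond the scatter, but no single-site step links those two compounds.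

Compound 4 `N#Cc1ccc(C2=C(c3ccccc3)C3(C=CC(=O)C=C3)OC2=O)cc1` is the next compound to be measured in this assay. It differs from compound 1 in one place: 4-cyanophenyl in place of 1-benzofuran-2-yl on a double-bonded ring carbon.

Within the data shown here, one measured step bears on this change. Going from compound 1 to compound 2, a 4-nitrophenyl group replaces the same 1-benzofuran-2-yl group at the same position, and no change at the digits printed from compound 1 to compound 2 (within the scatter). Among the measured compounds shown here, that step is the only guide available: an aryl group with one hydrogen-bond acceptor replacing the benzofuranyl group left the number where it was. Compound 4 carries a 4-cyanophenyl group, again with one hydrogen-bond acceptor, so the expected step is no change at the digits printed from compound 1 to compound 4 (within the scatter), no change beyond the scatter. Compound 4 is therefore estimated at 66600 nM, within a range of 25000 nM to 150000 nM.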

Compound 4, half-maximal inhibitory concentration: 8890 nM
Compound 4: middle estimate off by 7.5-fold (0.87 log units), on the high side; measured number below the stated range.
By their numbers in this assay, from the lowest: compounds 4 and 3 (each within the scatter of the next); then compounds 1 and 2 (each within the scatter of the next).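

At this double-bonded ring carbon the aryl groups are not interchangeable, as compounds 1 and 2 alone might have suggested: in this assay, 4-cyanophenyl in place of 1-benzofuran-2-yl gives a 7.5-fold lower number from compound 1 to compound 4 (0.87 log units; beyond the scatter), whereas 4-nitrophenyl in the same place gives no change at the digits printed from compound 1 to compound 2 (within the scatter). The sharpest contrast is the swap of cyano for nitro on an aromatic carbon, which gives a 7.5-fold lower number from compound 2 to compound 4 (0.87 log units; beyond the scatter), so a change confined to that one substituent is enough to move the number beyond the scatter, while 1-benzofuran-2-yl and 4-cyanophenyl carry the same count of hydrogen-bond acceptors, so that count does not follow the step. No measurement bears on why cyano and nitro part ways here.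

From the compounds shown here alone, it remains open whether the lower number belongs to the nitrile itself or would also appear with another substituent on the same aromatic carbon, such as an amine, a carboxylic acid or a methyl ester. Going by these compounds, it is equally open whether the step would hold if the phenyl group on the neighbouring ring atom gave way to a pyridine ring or a longer chain.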